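Notes on a hydroxamic acid series against a deacetylase

A few compounds are considered here, and "the series" means these few. Any claim that something is new, unique, unknown or untested is made for them only; others in the source may bear on it.

Compound 1 `Cc1ccc(-c2nc(CNc3ccc(C(=O)NO)cc3)n(-c3ccccc3)n2)cc1` carries a hydroxamic acid. In an assay on Sf9 cells for inhibition of protein deacetylase HDAC6 (Homo sapiens), read by fluorescence, with a stated time of 40 min, tested at 100 nM (on this read-out lower numbers stand for less inhibition and higher numbers for more inhibition at the one concentration tested (going by the name of the read-out)), compound 1 gives 62.2%, the highest of the two numbers at hand. Its nearest neighbour is compound 2 `NC(=O)c1ccc(NCc2nc(-c3ccccc3)nn2-c2ccccc2)cc1`, which carries a carboxamide in place of the hydroxamic acid. In this assay compound 2 gives -4.4%, a gap beyond the scatter. Going by the values given here, no pair of measured compounds differs in one place only, so no single change has a measured step.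

Compound 3 `Cc1ccc(-c2nc(CNc3ccc(C(=O)NO)cc3)n(-c3ccccc3)n2)o1` keeps the hydroxamic acid and differs from compound 1 on the aromatic carbon between two ring nitrogen atoms: 5-methylfuran-2-yl in place of 4-methylphenyl on an aromatic carbon. Compound 1 at 62.2% and compound 2 at -4.4% differ in the hydroxamic acid, which compound 3 retains. The step from the change is therefore expected to be small, within the scatter or modestly downward, estimated as a number 7.2 percentage points lower from compound 1 to compound 3 (within the scatter). Compound 3 is expected to give about 55% in this assay, with a range from 35% to 72%.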

Compound 3, a percentage reported as inhibition, at one concentration (the size of the read-out at that concentration, not a potency): 60.7%
Beside the measured number, compound 3's estimate is 5.7 percentage points below it; low and high end bracket the measured number.
By their numbers in this assay, from the lowest: compound 2; then compounds 3 and 1 (each within the scatter of the next).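

In this assay, the step of a number 1.5 percentage points lower from compound 1 to compound 3 (within the scatter) comes with 5-methylfuran-2-yl in place of 4-methylphenyl on the aromatic carbon between two ring nitrogen atoms. The position therefore accepts a five-membered aromatic ring with one oxygen as well as a six-membered aromatic ring of carbon only, with no change beyond the scatter, and the added hydrogen-bond acceptor on the entering group leaves the read-out within that scatter. No supporting data at hand account for this result.

Going by these compounds, both groups at this position are methyl-bearing aromatic rings, so it stays open whether an amine, a carboxylic acid or a longer alkyl chain on this carbon would be accepted in the same way. On these data alone, the role of the methyl group on either ring also stays open, as does the effect of any change to the phenyl group on the ring nitrogen.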